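The compounds below may be only part of what the source reports. "The series", "measured", "known", "first", "only" and "open" are said of these compounds alone.

Measured compounds in an in vivo functional assay on the whole organism for inhibition of 3-hydroxy-3-methylglutaryl-coenzyme A reductase (Rattus norvegicus), at a dose of 0.2 mg/kg by the oral route; on this read-out lower numbers stand for a weaker effect and higher numbers for a stronger effect at the one dose given:
compound 1 `Cc1nn(C(C)(C)C)c2nc(C3CC3)c(/C=C/[C@@H](O)C[C@@H](O)CC(=O)O)c(-c3ccc(F)cc3)c12` gives 4.5%
compound 2 `Cc1nn(C(C)(C)C)c2nc(C(C)C)c(/C=C/[C@@H](O)C[C@@H](O)CC(=O)O)c(-c3ccc(F)cc3)c12` gives 51.8%
compound 3 `CCc1c(C)sc2nc(C(C)C)c(/C=C/[C@@H](O)C[C@@H](O)CC(=O)O)c(-c3ccc(F)cc3)c12` gives 7.9%

Compound 3 stands second highest of the three numbers. Its nearest neighbour is compound 1, whose value lies within the scatter of that of compound 3, so no order between the two can be read. Compound 2 lies well beyond the scatter above compound 3. Going by the values given here, the only step between measured compounds that differ in one place is a number 47.3 percentage points higher from compound 1 to compound 2 (beyond the scatter), isopropyl in place of cyclopropyl on an aromatic carbon; it is large, but it concerns a different position from the one changed here.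

Compound 4 `Cc1cc2c(-c3ccc(F)cc3)c(/C=C/[C@@H](O)C[C@@H](O)CC(=O)O)c(C(C)C)nc2s1` differs from compound 3 by hydrogen in place of ethyl on an aromatic carbon, on an aromatic carbon of a five-membered aromatic ring with one sulfur, part of a fused system of two rings, next to the ring atom that bears a methyl group and two ring bonds from the ring sulfur. Among the compounds with values here, no measured step covers a change at this position, and no pair of measured compounds differs there. Without a guide, the expected step in this assay from compound 3 to compound 4 is none beyond the scatter, in either direction.

Compound 4 is therefore estimated at 8%, expected within 0% to 25%, that is an expected step of a number 0.1 percentage points higher from compound 3 to compound 4 (within the scatter).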

Compound 4, a percentage reported as inhibition, in the whole organism at one dose (the size of the read-out at that dose, not a potency): -21.5%
Estimate against measurement, compound 4: 29.5 percentage points above; measured number below the stated range.
By their numbers in this assay, from the lowest: compound 4; then compounds 1 and 3 (each within the scatter of the next); then compound 2.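

In this assay, going by these compounds alone, this position is not silent: hydrogen in place of ethyl on this aromatic carbon of the five-membered ring with one sulfur gives a number 29.4 percentage points lower from compound 3 to compound 4 (beyond the scatter), the first step read at this place. Compound 3 already gives a low number, 7.9%, and compound 4 gives -21.5%, a negative number, so the ethyl group still matters to the read-out on a compound that already scores low. Nothing in hand explains this step, and a single pair gives no account of why the read-out moves.

The compounds shown leave open how a methyl group, a longer chain such as propyl, or an amine on this same carbon would read, and so whether the read-out follows the size of the group there or ethyl is a special case. Also open, going by these compounds, are whether the same change would give a similar step on the core of compound 2, and whether the step would appear at all in a read-out on the isolated enzyme rather than at one oral dose in the whole organism.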